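The compounds below may be only part of what the source reports. "The series", "measured", "known", "first", "only" and "open" are said of these compounds alone.

Measured in a functional assay on HeLa cells (Homo sapiens) for antiproliferative activity, read by MTT assay, with a stated time of 72 h; on this read-out lower numbers stand for stronger inhibition and higher numbers for weaker inhibition:
- compound 1 `CCn1cc(C(=O)O)c(=O)c2cc(F)c(N3CCN(C(=N)NS(=O)(=O)c4ccccc4Cl)CC3)cc21`: 32 nM
- compound 2 `CCn1cc(C(=O)O)c(=O)c2cc(F)c(N3CCN(C(=N)NS(=O)(=O)c4ccccc4C(F)(F)F)CC3)cc21`: 32 nM

Compound 2, at 32 nM, stands level with compound 1 at the digits shown, so the series has no spread yet. The next compound, compound 3 `CCn1cc(C(=O)O)c(=O)c2cc(F)c(N3CCN(C(=N)NS(=O)(=O)c4ccc(Cl)cc4)CC3)cc21`, carries this change: 4-chlorophenyl in place of 2-(trifluoromethyl)phenyl on a sulfonyl sulfur. In words, 4-chlorophenyl replaces 2-(trifluoromethyl)phenyl on a sulfonyl sulfur.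

Among the measured compounds shown here, only one measured step bears on this. It is no change at the digits printed from compound 1 to compound 2 (within the scatter), the exchange of chloro for trifluoromethyl on an aromatic carbon, and it lies within the scatter. For the measured compounds named here, that step suggests some tolerance for this exchange, but it covers only two compounds. Going by the values given here, no measured step shows what happens when a substituent sits elsewhere on the aromatic ring, so the support is partial and the direction is open.

No step beyond the scatter is expected in this assay, and the expected move is a 1.4-fold higher number from compound 2 to compound 3 (0.15 log units; within the scatter), with a wide margin on either side. For compound 3 the estimated value is 45 nM, with an expected range of 15 nM to 140 nM.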

Compound 3, half-maximal inhibitory concentration: 32 nM
The estimate for compound 3 lay 1.4-fold (0.15 log units) above the measured number, within the range that was stated.
By their numbers in this assay, from the lowest: compounds 1, 2 and 3 (each within the scatter of the next).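

In this assay, 4-chlorophenyl in place of 2-(trifluoromethyl)phenyl on a sulfonyl sulfur gives no change at the digits printed from compound 2 to compound 3 (within the scatter), so the tolerance seen earlier for one substituent exchange now extends to a change in both the substituent and its place on the phenyl ring. The cleaner comparison keeps chloro as the substituent: 4-chlorophenyl in place of 2-chlorophenyl gives no change at the digits printed from compound 1 to compound 3 (within the scatter), which separates the place of the chloro group from its identity and shows no response on this read-out. No supporting measurement bears on why the three values coincide.

As far as these compounds go, all three compounds carry a phenyl group with a single chloro or trifluoromethyl substituent on the sulfonyl sulfur, so it remains open whether the same tolerance holds for a phenyl ring bearing an amine or a carboxylic acid, or for a longer alkyl chain in place of the phenyl ring. With the sulfonyl portion varied only this far, the three matching values also leave open how much that portion contributes to the activity of the shared core.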